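The source may hold more compounds than are shown below. What is called first, only, known or untested is meant among the compounds shown, and "the series" means these compounds.

Measured so far in a functional assay on HCT-116 cells (Homo sapiens) for cytotoxicity, read by MTT assay, with a stated time of 48 h; on this read-out lower numbers stand for stronger inhibition and higher numbers for weaker inhibition:
compound 1 `O=C(/C=C/c1ccc2c(c1)B(O)OC2)c1cccs1` gives 14200 nM
compound 2 `CCOC(=O)c1ccc(C(=O)/C=C/c2ccc3c(c2)B(O)OC3)cc1` gives 7600 nM
compound 3 `Cc1ccc(C(=O)/C=C/c2ccc3c(c2)B(O)OC3)cc1C` gives 6100 nM

Among the three numbers, compound 1 stands highest. Its nearest neighbour is compound 2, whose lower number lies within the scatter of repeated measurements, so the two cannot be told apart. Compound 3 sits furthest away; its lower number lies beyond the scatter, so compound 3 does inhibit more strongly than compound 1 in this assay. Among the measured compounds shown here, of the gap between compound 2 and compound 3 only the two values themselves can be read, and no step between them is given.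

The not yet measured compound 4 `O=C(/C=C/c1ccc2c(c1)B(O)OC2)c1ccccc1O` keeps the shared core of compound 1 and differs from it in one place: 2-hydroxyphenyl in place of thiophen-2-yl on a carbonyl carbon. For the measured compounds named here, no measured pair shows this same change, so the expectation rests only on the three values at hand. Compound 2 and compound 3, each carrying a six-membered carbon ring on the carbonyl carbon, both give lower numbers than compound 1, and on that basis compound 4 is expected to land somewhat below compound 1 as well, though possibly not beyond the scatter.

The step from compound 1 to compound 4 is estimated as a 1.8-fold lower number from compound 1 to compound 4 (0.25 log units; within the scatter).

For compound 4 in this assay the expected value is 8000 nM, within a range from 3000 nM to 22000 nM.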

Compound 4, half-maximal inhibitory concentration: 77900 nM
Compound 4: the middle estimate sits 9.7-fold (0.99 log units) below what was measured; measured number outside the range, above it.
By their numbers in this assay, from the lowest: compounds 3, 2 and 1 (each within the scatter of the next, the first and the last beyond it); then compound 4.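

In this assay, 2-hydroxyphenyl in place of thiophen-2-yl on a carbonyl carbon gives a 5.5-fold higher number from compound 1 to compound 4 (0.74 log units; beyond the scatter) and so shows that the group at this position can shift the number upward, which the first three compounds did not show. A six-membered aromatic ring of carbon only on the carbonyl carbon does not by itself go with a lower number: compound 4 carries such a ring and gives 77900 nM in this read-out, while compound 2 gives 7600 nM and compound 3 gives 6100 nM with rings that bear other groups. No measurement at hand bears on the reason for the higher number of compound 4.

The compounds shown leave open whether the change follows from the hydroxyl group itself or from the ring that carries it, as none of them has a plain phenyl ring on the carbonyl carbon. They also leave open how a methoxy group or an amine in place of that hydroxyl group would read in this assay on the same core.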